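Trimming the ethoxy group back to a hydroxy

A few compounds are considered here, and "the series" means these few. Any claim that something is new, unique, unknown or untested is made for them only; others in the source may bear on it.

Measured compounds:
compound 1 `O=C(O)COc1ccc(NCc2cccc(-c3ccccc3F)c2)cc1F` — 36.5 nM
compound 2 `Cc1ccccc1-c1cccc(CNc2ccc(OCC(=O)O)c(F)c2)c1` — 4.8 nM
compound 3 `CCOc1ccc(-c2cccc(CNc3ccc(OCC(=O)O)c(F)c3)c2)c(C)c1` — 11.6 nM

All three were tested in a functional assay on CHO cells for agonist activity at Free fatty acid receptor 1 (Homo sapiens), read by FLIPR and calcium flux; on this read-out lower numbers stand for an effect already at smaller amounts and higher numbers for an effect only at larger amounts of compound. Compound 3 stands second highest of the three numbers: its nearest neighbour is compound 2, reached by a 2.4-fold higher number from compound 2 to compound 3 (0.38 log units; beyond the scatter), and its furthest is compound 1, from which a 3.1-fold lower number from compound 1 to compound 3 (0.50 log units; beyond the scatter) leads to it.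

Compound 4 `Cc1cc(O)ccc1-c1cccc(CNc2ccc(OCC(=O)O)c(F)c2)c1` is compound 3 with one change: hydrogen in place of ethyl on an oxygen on an aromatic ring. The oxygen stays in place; only the ethyl on it is removed.

For the measured compounds named here, two measured steps bear on this. The step of a 2.4-fold higher number from compound 2 to compound 3 (0.38 log units; beyond the scatter) shows that adding an ethoxy at this position raised the number by a modest margin, while a 3.1-fold lower number from compound 1 to compound 3 (0.50 log units; beyond the scatter) shows the whole 4-ethoxy-2-methylphenyl group lowering the number relative to 2-fluorophenyl. Neither step puts a hydroxy at this position, so compound 4 sits between compound 2 and compound 3 in structure and is expected to do so in number as well. A small lowering is therefore expected, a 1.5-fold lower number from compound 3 to compound 4 (0.16 log units; within the scatter), within or just beyond the scatter.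

Compound 4 is estimated at 8 nM, with a range from 3 nM to 25 nM in this assay.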

Compound 4, half-maximal effective concentration: 69.6 nM
Compound 4: the middle estimate sits 8.7-fold (0.94 log units) below what was measured; measured number above the stated range.
By their numbers in this assay, from the lowest: compound 2; then compound 3; then compounds 1 and 4 (each within the scatter of the next).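

In this assay the ethyl on this oxygen proves to matter: removing it gives a 6.0-fold higher number from compound 3 to compound 4 (0.78 log units; beyond the scatter), so the hydroxy compound does not land between the hydrogen and ethoxy compounds but has a higher number than both. Measured against hydrogen on the same aromatic carbon, hydroxy gives a 15-fold higher number from compound 2 to compound 4 (1.16 log units; beyond the scatter), a much larger rise than the one ethoxy gives, a 2.4-fold higher number from compound 2 to compound 3 (0.38 log units; beyond the scatter), so the outcome here depends on what the oxygen carries and not simply on an oxygen being present. The lower number that the 4-ethoxy-2-methylphenyl group showed against 2-fluorophenyl also does not carry over to 4-hydroxy-2-methylphenyl: a 1.9-fold higher number from compound 1 to compound 4 (0.28 log units; within the scatter) leaves those two compounds within the scatter of each other.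

Nothing in the available data explains why swapping ethyl for hydrogen on this oxygen has this effect. From the compounds shown here alone, it also remains open whether a methoxy, a longer chain such as propoxy, or an amine at this position would behave more like the ethoxy or more like the hydroxy.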